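Removing a ring methyl and microsomal clearance

The source may hold more compounds than are shown below. What is called first, only, known or untested is meant among the compounds shown, and "the series" means these compounds.

Three amide compounds sharing one core were tested. Compound 1 `Cc1ccc2[nH]c(C(=O)N[C@H]3CN(S(=O)(=O)c4ccccc4)C[C@@H]3C(=O)NC[C@H]3CCCN3)cc2c1` gives a value that is a limit of the assay in an ADME assay on microsomes from liver (Homo sapiens) for metabolic stability (on this read-out lower numbers stand for slow clearance and higher numbers for fast clearance), namely < 3 mL.min-1.g-1. Compound 2 `Cc1ccc2[nH]c(C(=O)N[C@H]3CN(S(=O)(=O)c4ccccc4)C[C@@H]3C(=O)NC[C@H]3CCCN3C)cc2c1` gives 22 mL.min-1.g-1, and compound 3 `Cc1ccc2[nH]c(C(=O)N[C@H]3CN(S(=O)(=O)c4ccccc4)C[C@@H]3C(=O)N[C@@H]3CCCN(C)C3)cc2c1` gives 50 mL.min-1.g-1. The change hydrogen in place of methyl on an amine nitrogen in a ring produced an at least 7.3-fold lower number from compound 2 to compound 1 (0.86 log units; beyond the scatter). Compound 2 and compound 3 differ in their cores by 1-methylpiperidin-3-yl in place of (1-methylpyrrolidin-2-yl)methyl on an amide-type nitrogen, giving a 2.3-fold higher number from compound 2 to compound 3 (0.36 log units; beyond the scatter). Compound 4 `Cc1ccc2[nH]c(C(=O)N[C@H]3CN(S(=O)(=O)c4ccccc4)C[C@@H]3C(=O)N[C@@H]3CCCNC3)cc2c1` is unmeasured; it differs from compound 3 by hydrogen in place of methyl on an amine nitrogen in a ring. This is the same kind of change as from compound 2 to compound 1, but the place differs: there the amine nitrogen sits in a five-membered ring next to the ring atom that bears a large group, here in a six-membered ring two ring bonds from it. For compound 4 a step of a 7.1-fold lower number from compound 3 to compound 4 (0.85 log units; beyond the scatter) is expected, which rests on an at least 7.3-fold lower number from compound 2 to compound 1 (0.86 log units; beyond the scatter). The estimated value of compound 4 is therefore 7 mL.min-1.g-1.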

Compound 4, intrinsic clearance in microsomes in the Homo sapiens assay: 3 mL.min-1.g-1
Estimate against measurement, compound 4: 2.3-fold (0.37 log units) above; the measured number falls inside the stated range.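

In the Homo sapiens assay the new step is a 17-fold lower number from compound 3 to compound 4 (1.22 log units; beyond the scatter), and the piperidin-3-yl amide also shows a 7.3-fold lower number from compound 2 to compound 4 (0.87 log units; beyond the scatter). Hydrogen in place of methyl on the ring amine nitrogen therefore lowers the number on both cores, but whether it does so by the same amount stays unknown: the same change on two cores in the Homo sapiens assay, an at least 7.3-fold lower number (0.86 log units; beyond the scatter) from compound 2 to compound 1 and a 17-fold lower number (1.22 log units; beyond the scatter) from compound 3 to compound 4; the limit leaves it open whether they differ Compound 1 gives a limit of the assay: the limit of < 3 mL.min-1.g-1 in the Homo sapiens assay, at which 1 of the 4 values shown sits. In the Homo sapiens assay the remaining step is a number no lower from compound 1 to compound 4 (the limit leaves the size open), and its size cannot be read.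

In a physicochemical assay for lipophilicity, measured as octanol-water partition, at pH 7.4 (a lower number here means a more polar compound, a higher number a more lipophilic compound), compound 3 gives 2.7 and compound 4 gives 1.3, which is a number 1.40 log units lower from compound 3 to compound 4 (beyond the scatter). With only two cores, it stays open whether the lower clearance follows the drop in lipophilicity seen in the physicochemical assay: the measured distribution coefficient of compound 3, 2.7, and of compound 4, 1.3, a number 1.40 log units lower (beyond the scatter) The compounds shown also leave open how an ethyl or an acetyl group on this nitrogen would behave.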